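Alkyne substituent change and cytotoxicity in the series

This account rests on a few compounds, and the source may have more. Where it says the series, first, only, none or still open, it means among the compounds named here.

- compound 1 `COc1cccc(C#Cc2c([N+](=O)[O-])nc3n2CC(C)O3)c1`: 6410 nM
- compound 2 `CC1Cn2c(nc([N+](=O)[O-])c2C#CC2CC2)O1`: 14800 nM

In an ADME assay on HepG2 cells (Homo sapiens) for cytotoxicity, read by MTT assay, with a stated time of 24 h (on this read-out lower numbers stand for higher toxicity in this test and higher numbers for lower toxicity in this test), compound 2 stands highest of the two measured compounds at 14800 nM, beyond the scatter from compound 1. Compound 3 `CC1Cn2c(nc([N+](=O)[O-])c2C#Cc2cccc(N)c2)O1` has 3-aminophenyl in place of cyclopropyl on a triple-bonded carbon. Among the compounds with values here, no single-place step between measured compounds is available. The expectation rests on compound 1 at 6410 nM, which also holds a six-membered aromatic ring of carbon only on a triple-bonded carbon. A lower number is expected in this assay, with an estimated 2.1-fold lower number from compound 2 to compound 3 (0.33 log units; beyond the scatter). The estimate for compound 3 is 7000 nM, within a range of 2500 nM to 20000 nM.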

Compound 3, half-maximal cytotoxic concentration: 8300 nM
Beside the measured number, compound 3's estimate is 1.2-fold (0.07 log units) below it, and the stated range covers the measured number.
By their numbers in this assay, from the lowest: compounds 1, 3 and 2 (each within the scatter of the next, the first and the last beyond it).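

In this assay, 3-aminophenyl in place of cyclopropyl on a triple-bonded carbon gives a 1.8-fold lower number from compound 2 to compound 3 (0.25 log units; within the scatter), so these two groups are not separated at this position. Amino in place of methoxy on an aromatic carbon gives a 1.3-fold higher number from compound 1 to compound 3 (0.11 log units; within the scatter), so this read-out does not separate those two groups either. No measurement on hand offers an explanation for these numbers. Still open, on these data alone, is whether a carboxylic acid or a longer chain in place of the amino group would shift the number beyond the scatter. As far as these compounds go, whether a plain phenyl would do so is also open.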